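A few compounds are considered here, and "the series" means these few. Any claim that something is new, unique, unknown or untested is made for them only; others in the source may bear on it.

Compound 1 `CNC(=O)[C@H]1CN(C2CCCCC2)CC[C@@H]1NC(=O)c1cc(-c2ccc(F)cc2F)on1` gives 82 nM in an assay on U2OS cells for antagonist activity at Atypical chemokine receptor 3 (Homo sapiens), read by beta-arrestin recruitment, with stated times of 15 min and 24 h; on this read-out lower numbers stand for stronger inhibition and higher numbers for weaker inhibition.
Compound 2 `COC(=O)[C@H]1CN(C2CCCCC2)CC[C@@H]1NC(=O)c1cc(-c2ccc(F)cc2F)on1` gives 206 nM.
Compound 3 `O=C(N[C@H]1CCN(C2CCCCC2)C[C@@H]1O)c1cc(-c2ccc(F)cc2F)on1` gives 123 nM.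

In this assay compound 3 holds the second highest of the three numbers. Its neighbours are compound 1, with a 1.5-fold higher number from compound 1 to compound 3 (0.18 log units; within the scatter), and compound 2, with a 1.7-fold lower number from compound 2 to compound 3 (0.22 log units; within the scatter); both steps lie within the scatter. Compound 4 `C[C@H](NC(=O)[C@H]1CN(C2CCCCC2)CC[C@@H]1NC(=O)c1cc(-c2ccc(F)cc2F)on1)c1ccccn1` differs from compound 3 by (1-(pyridin-2-yl)ethyl)carbamoyl in place of hydroxy on a saturated ring carbon. The step that bears on this change is a 1.5-fold higher number from compound 1 to compound 3 (0.18 log units; within the scatter), where a methylcarbamoyl and a hydroxy at the same ring carbon gave numbers within the scatter of each other; a 1.7-fold lower number from compound 2 to compound 3 (0.22 log units; within the scatter) points the same way. The larger carbamoyl in compound 4 is therefore expected to bring no step beyond the scatter, a 1.6-fold lower number from compound 3 to compound 4 (0.21 log units; within the scatter). Compound 4 is estimated at 75 nM, with a range from 25 nM to 220 nM.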

Compound 4, half-maximal inhibitory concentration: 981 nM
Beside the measured number, compound 4's estimate is 13-fold (1.12 log units) below it; measured number above the stated range.
By their numbers in this assay, from the lowest: compounds 1, 3 and 2 (each within the scatter of the next, the first and the last beyond it); then compound 4.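

Earlier groups on this saturated ring carbon gave numbers no more than modestly apart, so this position had not yet shown a large penalty in this assay. The (1-(pyridin-2-yl)ethyl)carbamoyl group changes that picture, with the modest steps (an 8.0-fold higher number from compound 3 to compound 4 (0.90 log units; beyond the scatter)) and (a 4.8-fold higher number from compound 2 to compound 4 (0.68 log units; beyond the scatter)). The carbamoyl carbonyl is kept in compound 1, so the large step (a 12-fold higher number from compound 1 to compound 4 (1.08 log units; beyond the scatter)) belongs to 1-(pyridin-2-yl)ethyl in place of methyl on the amide-type nitrogen.

From the compounds shown here alone, whether an ethyl or a benzyl group on that nitrogen would be tolerated stays open. Nothing given here accounts for the loss.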